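Swapping the aminopyridine for a thiadiazole

This account rests on a few compounds, and the source may have more. Where it says the series, first, only, none or still open, it means among the compounds named here.

Compound 3 `CCC(C)(C)Cc1c[nH]c(CCc2ccc(-c3cccc(N)n3)cc2)n1` gives the lowest number of the three compounds measured in an in vitro assay on CHO cells for displacement of a labelled ligand from Bombesin receptor subtype-3 (Homo sapiens), read by scintillation counting, with a stated time of 2 h (on this read-out higher numbers stand for weaker inhibition and lower numbers for stronger inhibition), at 7.3 nM. Compound 1 `CCC(C)(C)Cc1c[nH]c(CCc2ccc(-c3ccncc3)cc2)n1` gives 101 nM and compound 2 `CCC(C)(C)Cc1c[nH]c(CCc2ccc(-c3cnccn3)cc2)n1` gives 51 nM. The steps of a 14-fold lower number from compound 1 to compound 3 (1.14 log units; beyond the scatter) and a 7.0-fold lower number from compound 2 to compound 3 (0.84 log units; beyond the scatter) both lie beyond the scatter, whereas a 2.0-fold lower number from compound 1 to compound 2 (0.30 log units; within the scatter) does not. Compound 4 `CCC(C)(C)Cc1c[nH]c(CCc2ccc(-c3csnn3)cc2)n1` differs from compound 3 by 1,2,3-thiadiazol-4-yl in place of 6-aminopyridin-2-yl on an aromatic carbon. Both measured steps bearing on this change ran toward the 6-aminopyridin-2-yl group, and because a 14-fold lower number from compound 1 to compound 3 (1.14 log units; beyond the scatter) and a 7.0-fold lower number from compound 2 to compound 3 (0.84 log units; beyond the scatter) lowered the number on arrival, its removal is expected to raise the number in this assay. The expected step is an 8.2-fold higher number from compound 3 to compound 4 (0.91 log units; beyond the scatter). Compound 4 is therefore estimated at 60 nM, within a range from 20 nM to 200 nM.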

Compound 4, half-maximal inhibitory concentration: 45 nM
The estimate for compound 4 lay 1.3-fold (0.12 log units) above the measured number; measured number inside the range.
By their numbers in this assay, from the lowest: compound 3; then compounds 4, 2 and 1 (each within the scatter of the next, the first and the last beyond it).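

In this assay, the 1,2,3-thiadiazol-4-yl group does not keep the level of the 6-aminopyridin-2-yl group, giving a 6.2-fold higher number from compound 3 to compound 4 (0.79 log units; beyond the scatter). It is indistinguishable from the pyrazin-2-yl group, with a 1.1-fold lower number from compound 2 to compound 4 (0.05 log units; within the scatter), yet it still separates from the pyridin-4-yl group, with a 2.2-fold lower number from compound 1 to compound 4 (0.35 log units; beyond the scatter). Of the four groups, only the 6-aminopyridin-2-yl group carries a hydrogen-bond donor, and compound 3 stands alone at the low end, although nothing here gives a reason for this. Going by these compounds, whether an amine on the pyrazine or thiadiazole ring would bring the number back down remains open.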